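The source may report more compounds than this note shows. Statements on the series, on what has been measured and on what is new or still open speak of the compounds shown alone.

Compound 1 `Cc1cccc(/C(N)=N/NC(=S)N2CCCCC2)n1`, compound 2 `N/C(=N\NC(=S)N1CCOCC1)c1ccc(F)cn1` and compound 3 `N/C(=N\NC(=S)N1CCN(c2ccccn2)CC1)c1ccc(F)cn1` were measured in a functional assay on A-375 cells (Homo sapiens) for cytotoxicity, read by MTT assay, with a stated time of 72 h, tested at 1 uM; a higher number here means more inhibition of growth at the concentration tested, a lower number less inhibition of growth. Compound 1 gives 49.9%, compound 2 gives 44.5% and compound 3 gives 49.3% in this assay. Compound 3 stands second highest of the three numbers; its nearest neighbour is compound 1 and its furthest is compound 2, both within the scatter, so no order among the three can be read. Compound 4 `N/C(=N\NC(=S)N1CCN(c2ccccn2)CC1)c1ccccn1` differs from compound 3 by hydrogen in place of fluoro on an aromatic carbon. For the measured compounds named here, no step between measured compounds covers this change. Since all three measured values lie within the scatter of one another, the expected step of a number 2.3 percentage points lower from compound 3 to compound 4 (within the scatter) is none beyond the scatter. Compound 4 is expected to give 47%, between 35% and 59%, because compound 3 gives 49.3%.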

Compound 4, percent growth inhibition at one concentration: 70%
Estimate against measurement, compound 4: 23 percentage points below; measured number above the stated range.
By their numbers in this assay, from the lowest: compounds 2, 3 and 1 (each within the scatter of the next); then compound 4.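

In this assay, hydrogen in place of fluoro on the aromatic carbon para to a large group gives a number 20.7 percentage points higher from compound 3 to compound 4 (beyond the scatter) and is the only step shown that lies beyond the scatter. The earlier compounds shown here, all within the scatter of one another, gave no sign that this assay responds to the group at this position. Nothing measured here speaks to the reason for this step. From the compounds shown here alone, whether chloro, methoxy or an amine at this place would stand closer to compound 3 or to compound 4 stays open. Also open, going by these compounds, is whether the same change would give a similar step from compound 2.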